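The source may report more compounds than this note shows. Statements on the series, on what has been measured and on what is new or still open speak of the compounds shown alone.

Measured compounds:
Compound 1 `C=CC(=O)Nc1ccccc1CN(C(=O)Nc1cccc(C(F)(F)F)c1)C1CCN(C(C)CCC)CC1`: 10200 nM
Compound 2 `C#CCSc1nc(Sc2nncs2)c(C#N)c(-c2cc(OC)c(OC)c(OC)c2)n1`: 9820 nM
Compound 3 `C#CCSc1nc(Sc2nccs2)c(C#N)c(-c2ccc(Cl)cc2)n1`: 3230 nM

All three were tested in a functional assay on MCF7 cells (Homo sapiens) for antiproliferative activity, read by MTT assay, with a stated time of 72 h; a lower number here means a stronger inhibitor, a higher number a weaker inhibitor. Compound 2 stands with the second highest of the three numbers. Its number and that of compound 1 lie within the usual scatter of repeated measurements, so the two cannot be told apart. Compound 3 gives a lower number, and that gap is beyond the scatter.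

Compound 4 `C#CCSc1nc(Sc2ccccn2)c(C#N)c(-c2cc(OC)c(OC)c(OC)c2)n1` has not yet been measured in this assay. It differs from compound 2 in one place: pyridin-2-yl in place of 1,3,4-thiadiazol-2-yl on a sulfur. The rest of the structure is unchanged. Within the data shown here, no pair of measured compounds shows this exact exchange, so there is no measured step to lean on. Such a swap of one aromatic ring for another on a sulfur is expected to move the number in this assay only a little, if at all. The estimated step is a 1.2-fold lower number from compound 2 to compound 4 (0.09 log units; within the scatter). Compound 4 is therefore expected to give about 8000 nM, with a likely range from 2500 nM to 25000 nM.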

Compound 4, half-maximal inhibitory concentration: > 10000 nM
Compound 4: only a limit was reported; the forecaster's own chance of this, stated with the estimate: 10%; middle value at least 1.2-fold (0.09 log units) away from the limit.
By their numbers in this assay, from the lowest: compound 3; then compounds 2 and 1 (each within the scatter of the next).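

Among these compounds, this is the first measured exchange on this sulfur, since the earlier compounds offered no step between them. In this assay, compound 4 gives > 10000 nM, which is a limit of the assay and not a number. Putting pyridin-2-yl in place of 1,3,4-thiadiazol-2-yl therefore reads only as a floor, an at least 1.0-fold higher number from compound 2 to compound 4 (0.00 log units; that floor lies within the scatter), and the size of the change stays unknown because the reading stops at a limit: the limit of > 10000 nM in this assay, at which 1 of the 4 values shown sits.

Going by these compounds, how far the true number of compound 4 lies past that limit remains open. Also open, on these data alone, is how this position responds to groups of a different kind on the sulfur, such as a short chain ending in an amine or a carboxylic acid, in place of an aromatic ring.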